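The source may hold more compounds than are shown below. What is called first, only, known or untested is meant among the compounds shown, and "the series" means these compounds.

Three compounds sharing one core differ only in the aromatic group attached to it. Compound 1 `O=c1oc2ccccc2c2nc3c(ccc4cc[nH]c43)c(-c3ccc(Cl)cc3Cl)c12` carries a 2,4-dichlorophenyl group, compound 2 `O=c1oc2ccccc2c2nc3c(ccc4cc[nH]c43)c(-c3ccccn3)c12` a pyridin-2-yl group, and compound 3 `O=c1oc2ccccc2c2nc3c(ccc4cc[nH]c43)c(-c3cccc4ccccc34)c12` a naphthalen-1-yl group. In a functional assay on B16-F10 cells (Mus musculus) for cytotoxicity (on this read-out lower numbers stand for stronger inhibition and higher numbers for weaker inhibition), compound 1 gives 70700 nM, compound 2 gives 70700 nM and compound 3 gives 70700 nM, so compound 3 stands level with both of the others. The step of no change at the digits printed from compound 1 to compound 2 (within the scatter), the step of no change at the digits printed from compound 1 to compound 3 (within the scatter) and the step of no change at the digits printed from compound 2 to compound 3 (within the scatter) all stay within the scatter: exchanging one aromatic group for another at this position has not shifted the read-out among these three.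

Compound 4 `O=c1oc2ccccc2c2nc3c(ccc4cc[nH]c43)c(-c3cccc(Cl)c3Cl)c12` is the next member, differing from compound 3 by 2,3-dichlorophenyl in place of naphthalen-1-yl on an aromatic carbon. The three steps already seen bear directly on this change, since each exchanged the same attached group, and none moved the value. A step of no change at the digits printed from compound 3 to compound 4 (within the scatter) of no size beyond the scatter is therefore expected. Compound 4 is estimated at 70700 nM, with a range from 35000 nM to 141000 nM.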

Compound 4, half-maximal inhibitory concentration: 70700 nM
Estimate against measurement, compound 4: no gap at the digits printed; the measured number falls inside the stated range.
By their numbers in this assay, from the lowest: compounds 1, 2, 3 and 4 (each within the scatter of the next).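

Replacing naphthalen-1-yl with 2,3-dichlorophenyl swaps two six-membered aromatic carbon rings for one ring bearing two chlorine atoms, and this assay shows no change at the digits printed from compound 3 to compound 4 (within the scatter) for this change. Moving from the 2,4-dichlorophenyl to the 2,3-dichlorophenyl pattern gives no change at the digits printed from compound 1 to compound 4 (within the scatter) here, so this shift in chlorine placement leaves the reading where it was, and the exchange of pyridin-2-yl for 2,3-dichlorophenyl, with no change at the digits printed from compound 2 to compound 4 (within the scatter) as its result, matches that picture. No supporting data are available to explain this flat result.

As far as these compounds go, all four groups are aromatic rings, so the effect of an amine, a carboxylic acid or a longer alkyl chain at this position remains open. From the compounds shown here alone, whether any change elsewhere on the shared core would move the number also remains open.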